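Methylsulfanyl to methyl on the hydroxy-bearing ring

This account rests on a few compounds, and the source may have more. Where it says the series, first, only, none or still open, it means among the compounds named here.

Three compounds of the series have numbers in an assay on isolated protein for inhibition of solute carrier family 22 member 12 (Homo sapiens), tested at 3 uM; a lower number here means less inhibition, a higher number more inhibition at the concentration tested (going by the name of the read-out). Compound 1 `CCc1cc(C(=O)n2cccc2)cc(C#N)c1O` gives 83%. Compound 2 `CSc1cc(C(=O)N2CC=CC2)cc(C#N)c1O` gives 58%. Compound 3 `CCCc1cc(C(=O)N2CC=CC2)cc(C(F)(F)F)c1O` gives 49%. Compound 2 stands second highest of the three: its number sits close to that of compound 3, within the scatter, and well below that of compound 1, beyond the scatter. Within the data shown here, no pair among the measured compounds differs in one place only, so no measured step guides the next change directly.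

Compound 4 `Cc1cc(C(=O)N2CC=CC2)cc(C#N)c1O` differs from compound 2 as follows: methyl in place of methylsulfanyl on an aromatic carbon. The group that leaves is the methylsulfanyl, the group that enters is methyl, a single heavy atom. Among the measured compounds shown here, no measured pair shows the effect of this exchange on the read-out, and compound 1, which carries ethyl at that place, also differs in its amide ring and so cannot serve as a reference. A step of modest size, downward or none beyond the scatter, is expected from compound 2 to compound 4, as a number 8 percentage points lower from compound 2 to compound 4 (within the scatter). For compound 4 the inhibition is estimated at 50%, with a range from 30% to 70%.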

Compound 4, a percentage reported as inhibition, at one concentration (the size of the read-out at that concentration, not a potency): 25%
The estimate for compound 4 lay 25 percentage points above the measured number, outside the stated range (below it).
By their numbers in this assay, from the lowest: compound 4; then compounds 3 and 2 (each within the scatter of the next); then compound 1.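

The position ortho to a hydroxy group is sensitive in this assay, where methyl in place of methylsulfanyl gives a number 33 percentage points lower from compound 2 to compound 4 (beyond the scatter) with the nitrile and the amide ring unchanged. Among these compounds, this is the first single-place change, and it shows that the rest of compound 2 does not hold the read-out once this place carries only methyl. No measurement on these compounds accounts for the size of the step.

A single pair cannot separate the loss of sulfur from the loss of chain length, and the compounds with ethyl or propyl at this place also differ elsewhere. As far as these compounds go, whether a methoxy group or an ethylsulfanyl chain here, on the same amide ring and with the nitrile, would track compound 2 or compound 4 remains open.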